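Amine substituent swaps on the sulfonamide chain: stability notes

This account rests on a few compounds, and the source may have more. Where it says the series, first, only, none or still open, it means among the compounds named here.

Measured compounds:
compound 1, `CC(C)NCCS(=O)(=O)NC(=O)c1ccc(Nc2nc(NC3(c4ccc(Cl)cc4)CC3)nc(OCC(F)(F)F)n2)cc1`, 89%
compound 2, `CC(C)(C)CNCCS(=O)(=O)NC(=O)c1ccc(Nc2nc(NC3(c4ccc(Cl)cc4)CC3)nc(OCC(F)(F)F)n2)cc1`, 89%
compound 3, `CC(=O)NCCS(=O)(=O)NC(=O)c1ccc(Nc2nc(NC3(c4ccc(Cl)cc4)CC3)nc(OCC(F)(F)F)n2)cc1`, 95%

In an ADME assay on microsomes from liver (Homo sapiens) for metabolic stability, with a stated time of 10 min (on this read-out higher numbers stand for a more stable compound and lower numbers for a less stable compound), compound 1 stands level with compound 2, the two together the lowest of the three numbers; compound 3 sits a number 6 percentage points higher from compound 1 to compound 3 (within the scatter), which is within the scatter. Compound 4, `O=C(NS(=O)(=O)CCNCc1ccccc1)c1ccc(Nc2nc(NC3(c4ccc(Cl)cc4)CC3)nc(OCC(F)(F)F)n2)cc1`, is not yet measured. It differs from compound 1 as follows: benzyl in place of isopropyl on an amine nitrogen. Going by the values given here, the steps that bear on it are the earlier swaps on the same amine nitrogen: no change at the digits printed from compound 1 to compound 2 (within the scatter) and a number 6 percentage points higher from compound 1 to compound 3 (within the scatter). Neither moved the read-out beyond the scatter, so no step beyond the scatter is expected in this assay for compound 4 either; the expected step is a number 3 percentage points lower from compound 1 to compound 4 (within the scatter). Compound 4 is therefore estimated at 86%, with a range from 72% to 96%.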

Compound 4, percent of the compound remaining: 99%
Compound 4: the middle estimate sits 13 percentage points below what was measured; the whole stated range lies below it.
By their numbers in this assay, from the lowest: compounds 1, 2, 3 and 4 (each within the scatter of the next).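

In this assay a benzyl group, with its six-membered aromatic ring, is taken on this amine nitrogen with every step inside the scatter (a number 10 percentage points higher from compound 1 to compound 4 (within the scatter); a number 4 percentage points higher from compound 3 to compound 4 (within the scatter); a number 10 percentage points higher from compound 2 to compound 4 (within the scatter)). This position therefore holds the read-out level across a ring-bearing group as well as the isopropyl, neopentyl and acetyl groups. No measurement here bears on a cause for this. On these data alone, whether a phenethyl group, a carboxylic acid or a second substituent on this nitrogen would also stay within the scatter remains open.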